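The source may hold more compounds than are shown below. What is called first, only, known or untested is meant among the compounds shown, and "the series" means these compounds.

Working notes on the series.

In a functional assay on PC-3 cells (Homo sapiens) for inhibition, read by MTT assay, with a stated time of 72 h (a higher number here means a weaker inhibitor, a lower number a stronger inhibitor), compound 1 `CC(C)n1ncc2c(C(=O)NCc3cn(-c4cccc(Br)c4)nn3)cccc21` gives 33700 nM. Compound 2 `Cc1ccc(-n2cc(CNC(=O)c3cccc4c3cnn4C(C)C)nn2)cc1` gives 39000 nM in this assay. For the measured compounds named here, the one step in the set, a 1.2-fold higher number from compound 1 to compound 2 (0.06 log units; within the scatter), replaces 3-bromophenyl with 4-methylphenyl on an aromatic nitrogen and leaves the number essentially where it was. Compound 2 holds the higher of the two numbers, but the two values lie within the scatter of each other, so no order between compound 1 and compound 2 can be read from them.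

Compound 3 `Cc1ccccc1-n1cc(CNC(=O)c2cccc3c2cnn3C(C)C)nn1` is not yet measured. Its change from compound 2 is 2-methylphenyl in place of 4-methylphenyl on an aromatic nitrogen. Going by the values given here, the only measured step bears on it indirectly: it also alters the phenyl ring on the same aromatic nitrogen, and it produced no movement beyond the scatter. Among the compounds with values here, no step in the set tests the 2-methylphenyl pattern itself, so the expectation rests on that single comparison alone. Compound 3 is therefore expected to stay close to compound 2, with an estimated step of no change at the digits printed from compound 2 to compound 3 (within the scatter) in this assay. The estimate for compound 3 is 39000 nM, within a range of 15000 nM to 95000 nM.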

Compound 3, half-maximal inhibitory concentration: 19200 nM
Beside the measured number, compound 3's estimate is 2.0-fold (0.31 log units) above it, and the stated range covers the measured number.
By their numbers in this assay, from the lowest: compounds 3, 1 and 2 (each within the scatter of the next, the first and the last beyond it).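

For the compounds shown here, compound 3 gives the first step at this position that goes beyond the scatter in this assay: moving the methyl group around the phenyl ring on the aromatic nitrogen, with the ring and atom count unchanged, gives a 2.0-fold lower number from compound 2 to compound 3 (0.31 log units; beyond the scatter), a modest effect. The earlier step between 3-bromophenyl and 4-methylphenyl showed no readable effect, so the arrangement of a methyl group on this ring can matter even though the exchange of those two substituted phenyl groups did not. Against 3-bromophenyl, however, 2-methylphenyl remains within the scatter (a 1.8-fold lower number from compound 1 to compound 3 (0.24 log units; within the scatter)), so compound 3 cannot be ordered against compound 1, and no measurement available here accounts for the shift from compound 2.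

The compounds shown leave open whether the effect belongs to the methyl group alone or would extend to a longer chain, such as ethyl, or to a different group, such as an amine or a carboxylic acid, on the same phenyl ring. They also leave open whether any change outside this phenyl ring, with the shared core altered, would move the number further than this modest step.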